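The source may hold more compounds than are shown below. What is called first, only, known or untested is meant among the compounds shown, and "the series" means these compounds.

Measured so far in a functional assay on A549 cells (Homo sapiens) for cytotoxicity, with a stated time of 48 h; a lower number here means a stronger inhibitor of growth, a higher number a weaker inhibitor of growth:
compound 1 `CCc1cc(-c2cc(N3C[C@H](O)[C@@H](O)C3)ccc2O)nc(N)n1` — 3000 nM
compound 2 `Nc1nc(-c2cc(N3C[C@H](O)[C@@H](O)C3)ccc2O)cc(C2CCCC2)n1` — 2000 nM
compound 3 `CN(C)c1cc(-c2cc(N3C[C@H](O)[C@@H](O)C3)ccc2O)nc(N)n1` — "not determined" (no result reported)

Among the two numbers, compound 2 has the lower one, and its nearest neighbour is compound 1, a gap that lies within the scatter. Compound 4 `Nc1nc(-c2cc(N3C[C@H](O)[C@@H](O)C3)ccc2O)cc(C2CCCCC2)n1` differs from compound 2 in one place: cyclohexyl in place of cyclopentyl on an aromatic carbon. Among the compounds with values here, the only measured step that bears on this position is a 1.5-fold lower number from compound 1 to compound 2 (0.18 log units; within the scatter), which likewise exchanged one carbon-only group for another on the same aromatic carbon and stayed within the scatter. From that single step, no change beyond the scatter is expected here. Compound 4 is therefore estimated at 2000 nM, with a range of 1000 nM to 4000 nM. The expected step of no change at the digits printed from compound 2 to compound 4 (within the scatter) is accordingly small.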

Compound 4, concentration for 50% growth inhibition: 1200 nM
The estimate for compound 4 lay 1.7-fold (0.22 log units) above the measured number; the measured number falls inside the stated range.
By their numbers in this assay, from the lowest: compounds 4, 2 and 1 (each within the scatter of the next, the first and the last beyond it).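

In this assay, cyclohexyl in place of cyclopentyl gives a 1.7-fold lower number from compound 2 to compound 4 (0.22 log units; within the scatter) and so does not separate these two rings on this aromatic carbon. However, cyclohexyl in place of ethyl gives a 2.5-fold lower number from compound 1 to compound 4 (0.40 log units; beyond the scatter) as the first step at this position to pass beyond the scatter, though only modestly. Nothing available gives a reason for this step.

On these data alone, it remains open whether a longer chain, a phenyl ring or an amine on this aromatic carbon would continue this trend among the carbon-only groups.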